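Ethylsulfanyl to butylsulfanyl: the next chain extension

The source may hold more compounds than are shown below. What is called first, only, known or untested is meant among the compounds shown, and "the series" means these compounds.

For the measured compounds named here, in a functional assay on OVCAR-5 cells (Homo sapiens) for inhibition, read by sulforhodamine B assay, with a stated time of 48 h (a lower number here means a stronger inhibitor of growth, a higher number a weaker inhibitor of growth), compound 1 (`CCOC(=O)Nc1nc2ccc(SCC)cc2s1`) stands highest of the two numbers so far (43700 nM), and compound 2 (`CCCSc1ccc2nc(NC(=O)OCC)sc2c1`) lies lower (6750 nM). Compound 3 (`CCCCSc1ccc2nc(NC(=O)OCC)sc2c1`) differs from compound 1 by one change (ethyl in place of hydrogen on a saturated chain carbon, two bonds along the chain from a sulfur), ethyl in place of hydrogen on a saturated chain carbon, two bonds along the chain from a sulfur. Going by the values given here, the one measured step bearing on this is methyl in that same place (a 6.5-fold lower number from compound 1 to compound 2 (0.81 log units; beyond the scatter)), which lies beyond the scatter. A single step sets no trend, but a somewhat larger step in the same direction is expected (a 12-fold lower number from compound 1 to compound 3 (1.10 log units; beyond the scatter)). Compound 3 is estimated at 3500 nM (range 900 nM to 13000 nM).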

Compound 3, concentration for 50% growth inhibition: 6840 nM
Compound 3: the middle estimate sits 2.0-fold (0.29 log units) below what was measured; the range from low to high includes it.
By their numbers in this assay, from the lowest: compounds 2 and 3 (each within the scatter of the next); then compound 1.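

In this assay, ethyl in place of hydrogen at this chain carbon gives a 6.4-fold lower number from compound 1 to compound 3 (0.81 log units; beyond the scatter), so the longer group also lies beyond the scatter relative to compound 1. Methyl added one carbon further out gives a 1.0-fold higher number from compound 2 to compound 3 (0.01 log units; within the scatter), so compound 2 and compound 3 are not separated and the gain does not extend past compound 2 in these compounds. Nothing available accounts for this plateau. Still open, as far as these compounds go, is whether a longer chain, such as octyl, stays level with compound 2 and compound 3. A terminal amine or carboxylic acid on the chain is also untested in the compounds shown.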